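Changing the tetrazolyl group of compound 3

The compounds below may be only part of what the source reports. "The series", "measured", "known", "first", "only" and "open" are said of these compounds alone.

In a functional assay on HUVEC cells (Homo sapiens), read by scintillation counting and thymidine incorporation, with a stated time of 24 h (a higher number here means a weaker inhibitor, a lower number a stronger inhibitor), compound 1 (`CCC(C)n1ncn(-c2ccc(N3CCN(c4ccc(OC[C@@H]5CO[C@@](CN6CCN(C)CC6)(c6ccc(Cl)cc6Cl)O5)cc4)CC3)cc2)c1=O`) gives 396 nM and compound 2 (`CCC(C)n1ncn(-c2ccc(N3CCN(c4ccc(OC[C@@H]5CO[C@@](Cn6cnc(C(F)(F)F)n6)(c6ccc(Cl)cc6Cl)O5)cc4)CC3)cc2)c1=O`) gives 270 nM while compound 3 (`CCC(C)n1ncn(-c2ccc(N3CCN(c4ccc(OC[C@@H]5CO[C@@](Cn6ncnn6)(c6ccc(Cl)cc6Cl)O5)cc4)CC3)cc2)c1=O`) gives 124 nM as the strongest of the three. The change to compound 4 (`CCC(C)n1ncn(-c2ccc(N3CCN(c4ccc(OC[C@@H]5CO[C@@](Cn6nnnc6C)(c6ccc(Cl)cc6Cl)O5)cc4)CC3)cc2)c1=O`) is 5-methyl-1H-tetrazol-1-yl in place of 2H-tetrazol-2-yl on a saturated chain carbon bound to a saturated ring carbon and puts 5-methyl-1H-tetrazol-1-yl in place of 2H-tetrazol-2-yl on a saturated chain carbon bound to a saturated ring carbon. Three measured swaps at this place bear on it, with a 1.5-fold lower number from compound 1 to compound 2 (0.17 log units; within the scatter) then a 3.2-fold lower number from compound 1 to compound 3 (0.50 log units; beyond the scatter) and a 2.2-fold lower number from compound 2 to compound 3 (0.34 log units; beyond the scatter) as their sizes. None of them adds a methyl to a tetrazolyl ring, so the direction is uncertain. The expected step is small, a 1.3-fold higher number from compound 3 to compound 4 (0.11 log units; within the scatter) in the estimate. In this assay the estimated value for compound 4 is 160 nM (range 65 nM to 380 nM).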

Compound 4, half-maximal inhibitory concentration: 101 nM
For compound 4 the middle estimate is 1.6-fold (0.20 log units) above the measured one; the range from low to high includes it.
By their numbers in this assay, from the lowest: compounds 4 and 3 (each within the scatter of the next); then compounds 2 and 1 (each within the scatter of the next).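

In this assay, moving to 5-methyl-1H-tetrazol-1-yl gives a 1.2-fold lower number from compound 3 to compound 4 (0.09 log units; within the scatter), so this place accepts a second tetrazolyl group, with its extra methyl, without a change beyond the scatter. That second tetrazolyl group also keeps the gap to the other two groups, with a 2.7-fold lower number from compound 2 to compound 4 (0.43 log units; beyond the scatter) and a 3.9-fold lower number from compound 1 to compound 4 (0.59 log units; beyond the scatter). No measurement shown explains these differences.

As far as these compounds go, the swap alters both the methyl and the ring attachment, so their separate contributions remain unknown, and a plain 1H-tetrazol-1-yl would separate them. From the compounds shown here alone, how a carboxylic acid would fare at this place also remains open.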